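The source may report more compounds than this note shows. Statements on the series, on what has been measured and on what is new or still open speak of the compounds shown alone.

Measured in a functional assay on cells (Homo sapiens) for antiproliferative activity, read by MTT assay, with a stated time of 48 h; a higher number here means a weaker inhibitor, a lower number a stronger inhibitor:
- compound 1 `CCN(CC)CCn1c(N)c(-c2nc3ccccc3[nH]2)c2nc(C#N)c(C#N)nc21`: 25400 nM
- compound 2 `CN(C)CCCn1c(N)c(-c2nc3ccccc3[nH]2)c2nc(C#N)c(C#N)nc21`: 1820 nM
- compound 3 `CN1CCN(CCCn2c(N)c(-c3nc4ccccc4[nH]3)c3nc(C#N)c(C#N)nc32)CC1`: 4520 nM

Compound 2 has the lowest number of the three. Its nearest neighbour on the numbers is compound 3, with a 2.5-fold higher number from compound 2 to compound 3 (0.40 log units; beyond the scatter), and its furthest is compound 1, with a 14-fold lower number from compound 1 to compound 2 (1.14 log units; beyond the scatter).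

The next compound is compound 4 `CN(C)CCCn1c(N)c(-c2nc3ccccc3n2C)c2nc(C#N)c(C#N)nc21`. It keeps the side chain of compound 2 and has methyl in place of hydrogen on an aromatic nitrogen.

Among the measured compounds shown here, all the measured steps, including a 5.6-fold lower number from compound 1 to compound 3 (0.75 log units; beyond the scatter), change the amine side chain. None touches this nitrogen, so the data give no direct reading of the new change. These steps serve only as a rough gauge of how far a single change can move the numbers in these three compounds, from modest to large.

A modest rise in this assay is expected, since compound 2 at 1820 nM already stands lowest of the three, though the direction remains uncertain. The expected change is a 2.7-fold higher number from compound 2 to compound 4 (0.44 log units; beyond the scatter). The estimate for compound 4 is 5000 nM. The expected range for compound 4 runs from 1500 nM to 20000 nM.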

Compound 4, half-maximal inhibitory concentration: 3670 nM
Beside the measured number, compound 4's estimate is 1.4-fold (0.13 log units) above it, within the range that was stated.
By their numbers in this assay, from the lowest: compounds 2, 4 and 3 (each within the scatter of the next, the first and the last beyond it); then compound 1.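

In this assay, among the compounds shown here, the first reading at this position, methyl in place of hydrogen on an aromatic nitrogen of the five-membered aromatic ring gives a 2.0-fold higher number from compound 2 to compound 4 (0.30 log units; within the scatter), so with the side chain of compound 2 held constant, the two compounds cannot be told apart. The hydrogen on this nitrogen can therefore be replaced by methyl without a shift beyond the scatter, whereas the side chain steps, such as a 2.5-fold higher number from compound 2 to compound 3 (0.40 log units; beyond the scatter), all lie beyond it. No measurement is available that bears on why this change leaves the number within the scatter.

It remains open whether a larger group on this nitrogen, such as ethyl, a longer alkyl chain or benzyl, would stay within the scatter as methyl does, since a single methyl is the only replacement shown. From the compounds shown here alone, it is equally open whether the same methyl would read alike on the diethylamino side chain of compound 1 or the 4-methylpiperazin-1-yl side chain of compound 3, because the reading here rests on one pair with one side chain.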